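Cytotoxicity notes: fused thiophene imines with benzothiazole

A few compounds are considered here, and "the series" means these few. Any claim that something is new, unique, unknown or untested is made for them only; others in the source may bear on it.

Measured in an ADME assay on cells (Rhabdomyosarcoma cell, Homo sapiens) for cytotoxicity, read by MTT assay, with a stated time of 72 h; a higher number here means that more compound is tolerated, a lower number that less compound is tolerated:
- compound 1 `Clc1ccc(/C=N/c2sc3c(c2-c2nc4ccccc4s2)CCC3)cc1`: 342 ug/mL
- compound 2 `Clc1ccc(/C=N/c2sc3c(c2-c2nc4ccccc4s2)CCCC3)cc1`: 367 ug/mL

Compound 2 holds the larger of the two numbers in this assay, but the gap to compound 1 lies within the scatter, so the pair read as equal. Compound 3 `O=[N+]([O-])c1ccccc1/C=N/c1sc2c(c1-c1nc3ccccc3s1)CCCC2` differs from compound 2 by 2-nitrophenyl in place of 4-chlorophenyl on a carbon with a double bond to nitrogen. Among the measured compounds shown here, no measured pair shows a change of this kind, so the size of the step is open. The expectation is a step of a 1.1-fold lower number from compound 2 to compound 3 (0.06 log units; within the scatter) that stays within the scatter, with no clear direction. Compound 3 is therefore estimated at 320 ug/mL, in a range from 160 ug/mL to 640 ug/mL.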

Compound 3, half-maximal cytotoxic concentration: 255 ug/mL
Beside the measured number, compound 3's estimate is 1.3-fold (0.10 log units) above it; measured number inside the range.
By their numbers in this assay, from the lowest: compounds 3, 1 and 2 (each within the scatter of the next).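

In this assay, among the compounds shown here, the first change at this place, on a carbon with a double bond to nitrogen, gives a 1.4-fold lower number from compound 2 to compound 3 (0.16 log units; within the scatter). The aryl group here can therefore go from 4-chlorophenyl to 2-nitrophenyl, with its added atoms and hydrogen-bond acceptors, without a step beyond the scatter. No supporting data bear on this result.

Still open, from the compounds shown here alone, is whether an amine or a carboxylic acid on the phenyl ring at this place would give a step beyond the scatter. Also open, going by these compounds, is whether 2-nitrophenyl reads the same on the core of compound 1.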